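This account rests on a few compounds, and the source may have more. Where it says the series, first, only, none or still open, it means among the compounds named here.

Compound 1 `CCCCCCCC(=O)OCCc1c(-c2ccccc2Cl)c2cc(Cl)ccc2[nH]c1=O` is an ester of the shared core carrying a heptyl group on its carbonyl carbon. Going by the values given here, in an ADME assay on HepG2 2.2.15 cells (Homo sapiens) for cytotoxicity (on this read-out lower numbers stand for higher toxicity in this test and higher numbers for lower toxicity in this test), compound 1 gives 78000 nM, the lowest of the two numbers measured so far. Its nearest neighbour is compound 2 `N#CCC(=O)OCCc1c(-c2ccccc2Cl)c2cc(Cl)ccc2[nH]c1=O`, which in this assay gives 100000 nM; the step is a 1.3-fold higher number from compound 1 to compound 2 (0.11 log units; within the scatter), so the two compounds cannot be told apart by this test.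

Compound 3 `O=C(OCCc1c(-c2ccccc2Cl)c2cc(Cl)ccc2[nH]c1=O)c1ccc([N+](=O)[O-])cc1` differs from compound 1 in one place: 4-nitrophenyl in place of heptyl on a carbonyl carbon. Among the compounds with values here, the only measured step that bears on this, the change of the chain on that same ester side of the molecule, was a 1.3-fold higher number from compound 1 to compound 2 (0.11 log units; within the scatter), so a change at this position has so far moved the read-out no further than repeated measurements themselves move it. The step expected here is therefore a 1.1-fold higher number from compound 1 to compound 3 (0.04 log units; within the scatter), that is, nothing beyond the scatter. Compound 3 is accordingly estimated at 85000 nM, within a range from 35000 nM to 200000 nM.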

Compound 3, half-maximal cytotoxic concentration: 1600000 nM
For compound 3 the middle estimate is 19-fold (1.27 log units) below the measured one; the whole stated range lies below it.
By their numbers in this assay, from the lowest: compounds 1 and 2 (each within the scatter of the next); then compound 3.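

Swapping heptyl for 4-nitrophenyl on the carbonyl carbon gives a 21-fold higher number from compound 1 to compound 3 (1.31 log units; beyond the scatter) in this assay, and swapping cyanomethyl for it gives a 16-fold higher number from compound 2 to compound 3 (1.20 log units; beyond the scatter). The ester side of the molecule is therefore not as silent as the two chain esters suggested: the read-out can move well beyond the scatter here, and since higher numbers mean lower toxicity in this test, compound 3 is the least toxic of the three. Going by these compounds alone, nothing measured so far accounts for this difference between compound 3 and the two chain esters.

On these data alone, it remains open whether the aromatic ring alone produces the change or whether the nitro group is needed as well. A plain phenyl ester or a 4-aminophenyl ester on the shared core would help separate these two possibilities.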